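This account rests on a few compounds, and the source may have more. Where it says the series, first, only, none or still open, it means among the compounds named here.

A small group of compounds sharing one core has been tested in an ADME assay on J774.A1 cells (Mus musculus) for cytotoxicity, read by MTT assay, with a stated time of 48 h; a lower number here means that less compound is tolerated, a higher number that more compound is tolerated. For compound 1 (`O=C(NCc1cccc(Br)c1)c1c([N+](=O)[O-])noc1-c1ccc([N+](=O)[O-])cc1`) the entry reads "not determined" (no result reported) and offers no number. Compound 2 (`O=C(Nc1ccccc1)c1c([N+](=O)[O-])noc1-c1ccc(Cl)cc1`) gives 89300 nM and compound 3 (`O=C(Nc1ccccc1)c1c([N+](=O)[O-])noc1-c1ccc(Cl)cc1Cl`) gives 67300 nM. For the measured compounds named here, compound 3 therefore holds one of only two numbers, and it cannot be told apart from compound 2. Going by the values given here, the one measured step (a 1.3-fold lower number from compound 2 to compound 3 (0.12 log units; within the scatter)) is chloro in place of hydrogen on an aromatic carbon.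

Compound 4 (`O=C(NCc1cccc(Cl)c1Cl)c1c([N+](=O)[O-])noc1-c1ccc(Cl)cc1Cl`) carries 2,3-dichlorobenzyl in place of phenyl on an amide-type nitrogen. Among the compounds with values here, no measured step covers a change at that nitrogen, so the step from compound 2 is only a loose guide to the added chloro groups. Little movement beyond the scatter is therefore expected in this assay, with a weak lean towards a lower number. The estimated step is small (a 1.5-fold lower number from compound 3 to compound 4 (0.17 log units; within the scatter)). For compound 4 the expected value is 45000 nM in an estimated range from 15000 nM to 110000 nM overall.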

Compound 4, half-maximal cytotoxic concentration: 81800 nM
The estimate for compound 4 lay 1.8-fold (0.26 log units) below the measured number, and the stated range covers the measured number.
By their numbers in this assay, from the lowest: compounds 3, 4 and 2 (each within the scatter of the next).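

For the compounds shown here, putting 2,3-dichlorobenzyl in place of phenyl on the amide-type nitrogen is the first change at this position with a readable result, and in this assay it gives a 1.2-fold higher number from compound 3 to compound 4 (0.08 log units; within the scatter) and leaves compound 3 and compound 4 level. For these two compounds, then, a larger group at this nitrogen, with two chloro groups on its ring, makes no clear difference to how much compound the cells tolerate. No measurement offered here accounts for this result.

On these data alone, this single step adds the chloro groups and the carbon that links the ring to the nitrogen together, so their separate contributions remain unknown. As far as these compounds go, it also remains open how the number would respond at this nitrogen to a group of a different kind, such as an aminoethyl chain or a carboxylic acid.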